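Dropping the Aminoethyl Chain: Will Inhibition Return?

The source may hold more compounds than are shown below. What is called first, only, known or untested is meant among the compounds shown, and "the series" means these compounds.

Of the compounds shown here, three sharing one core have been tested in an assay for inhibition of Tryptophan 2,3-dioxygenase (Homo sapiens), with stated times of 10 min and 60 min; on this read-out higher numbers stand for weaker inhibition and lower numbers for stronger inhibition. Compound 1 `Nc1cccc(CNc2cc(C(F)(F)F)cc3[nH]ncc23)c1` gives 2510 nM in this assay. Compound 2 `FC(F)(F)c1cc(NCc2cccc3sccc23)c2cn[nH]c2c1` reaches only a limit of the assay, > 100000 nM, so no number is known for it. Compound 3 `NCCn1ncc2c(NCc3ccccc3[N+](=O)[O-])cc(C(F)(F)F)cc21` likewise stops at a limit, > 100000 nM. Among the compounds with values here, compound 3 therefore stands at the weak end of what has been seen, described only by the limit of > 100000 nM in this assay, at which 2 of the 3 values shown sit, and no single step between two measured compounds has been worked out.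

Compound 4 `O=[N+]([O-])c1ccccc1CNc1cc(C(F)(F)F)cc2[nH]ncc12` differs from compound 3 in one place: hydrogen in place of 2-aminoethyl on an aromatic nitrogen. The bare ring nitrogen it gains is the form present in compound 1 and compound 2, which sit far apart in this assay, so the effect of the change is uncertain. A gain in inhibition that goes well beyond the usual scatter is expected, but a number inside the range of the assay is far from certain. Compound 4 is estimated at 40000 nM, between 3000 nM and 100000 nM. The expected step is an at least 2.5-fold lower number from compound 3 to compound 4 (0.39 log units; beyond the scatter).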

Compound 4, half-maximal inhibitory concentration: 2550 nM
Estimate against measurement, compound 4: 16-fold (1.20 log units) above; measured number below the stated range.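

On this aromatic nitrogen, the group present decides whether inhibition can be measured at all: hydrogen in place of 2-aminoethyl gives an at least 39-fold lower number from compound 3 to compound 4 (1.59 log units; beyond the scatter) in this assay. Within the data shown here, this is the first pair that changes only this position, and it shows that the rest of the structure of compound 3 can give a value inside the range of the assay once the chain is gone. From the compounds shown here alone, the step is only a minimum, and its true size is unknown, because compound 3 is described by a limit rather than a number: the limit of > 100000 nM in this assay, at which 2 of the 4 values shown sit.

Going by these compounds, it remains open whether a methyl group on this nitrogen would keep inhibition, or whether an ethyl chain without its amine would lose it as 2-aminoethyl does. A single pair also cannot show whether the same step would hold with the other groups carried by the shared core.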